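A few compounds are considered here, and "the series" means these few. Any claim that something is new, unique, unknown or untested is made for them only; others in the source may bear on it.

Four related compounds are compared here. Compound 1 `O=S(=O)(c1cc(F)cc(F)c1)c1cnc2c(F)cccc2c1-c1ccccc1F` and compound 2 `COc1cccc(-c2c(S(=O)(=O)c3cc(F)cc(F)c3)cnc3c(F)cccc23)c1` are built on one core; compound 3 `COc1cccc(-c2c(S(=O)(=O)c3ccc(F)c(F)c3)cnc3cc(F)ccc23)c1` and compound 4 `O=S(=O)(c1ccc(F)c(F)c1)c1cnc2cc(F)ccc2c1-c1ccccc1F` are built on another, and how the two cores differ is not broken down here. In an ADME assay on microsomes from liver (Homo sapiens) for metabolic stability, tested at 2.5 uM (a lower number here means slower removal, a higher number faster removal of the compound), compound 1 gives 0.09 mL/min, compound 2 gives 2.76 mL/min, and compound 3 gives 1.77 mL/min. The change 2-fluorophenyl in place of 3-methoxyphenyl on an aromatic carbon brought a 31-fold lower number from compound 2 to compound 1 (1.49 log units; beyond the scatter). The same change, (2-fluorophenyl in place of 3-methoxyphenyl on an aromatic carbon), connects the two compounds on the second core, and the place of the change is described in the same words in both cases. Among the compounds with values here, the expected step is a 20-fold lower number from compound 3 to compound 4 (1.29 log units; beyond the scatter), which rests on the single earlier step of a 31-fold lower number from compound 2 to compound 1 (1.49 log units; beyond the scatter). Compound 4 is therefore estimated at 0.09 mL/min, likely falling between 0.03 mL/min and 0.4 mL/min.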

Compound 4, intrinsic clearance in a liver preparation (reported as CLH), per the amount of preparation that the assay uses: 0.79 mL/min
The estimate for compound 4 lay 8.8-fold (0.94 log units) below the measured number; measured number outside the range, above it.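

In this assay, putting 2-fluorophenyl in place of 3-methoxyphenyl again goes with a fall, a 2.2-fold lower number from compound 3 to compound 4 (0.35 log units; beyond the scatter), so the direction of the change carries over to the second core. Its size does not carry over, and the two steps clearly differ: the same change on two cores in this assay, a 31-fold lower number (1.49 log units; beyond the scatter) from compound 2 to compound 1 and a 2.2-fold lower number (0.35 log units; beyond the scatter) from compound 3 to compound 4, 14-fold (1.14 log units) apart, beyond the scatter of two such steps. This does not show which difference between the two cores sets the size of the step, and two cores are too few to predict the step on a third.

The compounds shown leave open how an amine, a carboxylic acid or a longer alkyl chain would behave on this same aromatic carbon. They also leave open whether the change would keep its direction on any further core.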